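This account rests on a few compounds, and the source may have more. Where it says the series, first, only, none or still open, it means among the compounds named here.

Measured compounds:
- compound 1 `Cc1ccc(C(/C=C/c2ccc(F)cc2)=N\Nc2nncc3ccccc23)cc1`: 7 nM
- compound 2 `Clc1ccc(C(/C=C/c2ccccc2)=N\Nc2nncc3ccccc23)cc1`: 9.6 nM

Both compounds share the same core and differ in the substitution of the two outer aromatic rings. In a functional assay on NCI-H460 cells (Homo sapiens) for antiproliferative activity, read by sulforhodamine B assay, with a stated time of 72 h (on this read-out lower numbers stand for stronger inhibition and higher numbers for weaker inhibition), compound 1 gives 7 nM and compound 2 gives 9.6 nM; the two numbers lie within the scatter of each other, so no order between them can be read. Compound 2 thus stands alongside compound 1 rather than apart from it.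

Compound 3 `C(=C/c1ccccc1)\C(=N\Nc1nncc2ccccc12)c1ccccc1` follows from compound 2 by hydrogen in place of chloro on an aromatic carbon, the change sitting on an aromatic carbon of a six-membered aromatic ring of carbon only, para to a large group. Within the data shown here, no measured pair tells the size of this step. Since compound 1 and compound 2 sit close together, the step is expected to be small in this assay, at most a modest loss that may not exceed the scatter. Compound 3 is expected near 15 nM, in the range 5 nM to 45 nM. The expected step of a 1.6-fold higher number from compound 2 to compound 3 (0.19 log units; within the scatter) is small.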

Compound 3, half-maximal inhibitory concentration: 5.7 nM
Beside the measured number, compound 3's estimate is 2.6-fold (0.42 log units) above it; measured number inside the range.
By their numbers in this assay, from the lowest: compounds 3, 1 and 2 (each within the scatter of the next).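

In this assay, the 4-chlorophenyl to phenyl change gives a 1.7-fold lower number from compound 2 to compound 3 (0.23 log units; within the scatter), so hydrogen can stand in place of chloro on this aromatic carbon, para to a large group, without a change that can be read. Among these compounds, this is the first comparison that differs in one place only, and it shows that chloro at this position is not needed for a number in this low range. No independent measurement bears on this result, so it rests on the assay numbers alone.

Going by these compounds, whether a larger or charged group at this place, such as an amine, a carboxylic acid or a longer alkyl chain, would stay within this range remains open. On these data alone, the separate contributions of the methyl and fluoro groups of compound 1 also remain open, as it differs from compound 3 in two places.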